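This account rests on a few compounds, and the source may have more. Where it says the series, first, only, none or still open, it means among the compounds named here.

Compound 1 `COc1ccc(CNC(=O)c2c(C)nc3cc(C)ccn23)cc1`: 0.28 h
Compound 2 `COc1cccc(CNC(=O)c2c(C)nc3cc(C)ccn23)c1`: 0.33 h

In an in vivo ADME assay on the whole organism (strain Sprague-Dawley) for metabolic stability, with Rattus norvegicus as the target, at a dose of 1 mg/kg by the intravenous route (a higher number here means that the compound lasts longer, a lower number that the compound disappears faster), compound 1 gives 0.28 h and compound 2 gives 0.33 h, so the two lie within the usual scatter of each other. Compound 3 `Cc1ccn2c(C(=O)NCc3ccc(Cl)cc3)c(C)nc2c1` keeps the core of compound 1 and carries chloro in place of methoxy on an aromatic carbon, para to a large group: chloro in place of methoxy on an aromatic carbon. Within the data shown here, no measured pair shows what this swap does, so only a modest rise is expected, perhaps not much beyond the scatter. The expected change is a 1.8-fold higher number from compound 1 to compound 3 (0.25 log units; within the scatter). For compound 3 the estimated half-life is 0.5 h, with an expected range of 0.25 h to 1 h.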

Compound 3, half-life in the Rattus norvegicus assay: 0.4 h
The estimate for compound 3 lay 1.3-fold (0.10 log units) above the measured number; the range from low to high includes it.
By their numbers in the Rattus norvegicus assay, from the lowest: compounds 1, 2 and 3 (each within the scatter of the next).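

Compounds 1 and 2 could not show what replacing the methoxy group does, but this pair can. With chloro in place of methoxy on the aromatic carbon para to a large group, the Rattus norvegicus assay shows a 1.4-fold higher number from compound 1 to compound 3 (0.15 log units; within the scatter), so this change does not clearly alter how long the compound lasts. The same change has a clear effect in a physicochemical assay for solubility, in phosphate buffer, at pH 7.4 (on this read-out lower numbers stand for lower solubility and higher numbers for higher solubility), where compound 1 gives 148000 nM and compound 3 gives 25000 nM: the measured solubility of compound 1, 148000 nM, and of compound 3, 25000 nM, a 5.9-fold lower number (0.77 log units; beyond the scatter).

As far as these compounds go, it remains open whether a different group at this position, such as an amine or a carboxylic acid, would clearly change half-life or solubility.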